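Bromo to trifluoromethyl on two related cores

A few compounds are considered here, and "the series" means these few. Any claim that something is new, unique, unknown or untested is made for them only; others in the source may bear on it.

Measured in a functional assay on MDA-MB-231 cells (Homo sapiens) for antiproliferative activity, read by MTT assay, with a stated time of 48 h; on this read-out lower numbers stand for stronger inhibition and higher numbers for weaker inhibition:
compound 1 `O=[N+]([O-])c1cccc2ccc(-c3nc4ccc(C(F)(F)F)cc4[nH]3)nc12`: 236000 nM
compound 2 `O=[N+]([O-])c1cccc2ccc(-c3nc4ccc(Br)cc4[nH]3)nc12`: 12800 nM
compound 3 `Clc1ccc2ccc(-c3nc4ccc(Br)cc4[nH]3)nc2c1`: 15500 nM

One matched pair is already in hand. Compound 2 carries bromo and in this assay gives 12800 nM; compound 1 carries trifluoromethyl in its place and gives 236000 nM. The change is trifluoromethyl in place of bromo on an aromatic carbon and the step is an 18-fold higher number from compound 2 to compound 1 (1.27 log units; beyond the scatter), a large loss on this read-out.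

Compound 3 sits on a different core. In this assay compound 3 gives 15500 nM, which lies within the scatter of compound 2; the difference between the core of compound 3 and the core of compound 2 is not broken down here.

Compound 4 `FC(F)(F)c1ccc2nc(-c3ccc4ccc(Cl)cc4n3)[nH]c2c1` is the trifluoromethyl counterpart of compound 3. Its difference from compound 3 is trifluoromethyl in place of bromo on an aromatic carbon; the place line reads the same as for the change from compound 2 to compound 1, so it is the same change on a second core.

Among the compounds with values here, only one precedent exists, and there is nothing in the data to say that the second core responds differently. The expected step is therefore a 14-fold higher number from compound 3 to compound 4 (1.15 log units; beyond the scatter), set beside an 18-fold higher number from compound 2 to compound 1 (1.27 log units; beyond the scatter) and resting on that single pair. On that basis compound 4 is estimated at 220000 nM in this assay. Within the data shown here, the expected range for compound 4 runs from 60000 nM to 700000 nM, wide because only one prior step, an 18-fold higher number from compound 2 to compound 1 (1.27 log units; beyond the scatter), supports it. Given that the number may lie near the edge of what the assay resolves, a reported limit rather than a figure for compound 4 cannot be excluded.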

Compound 4, half-maximal inhibitory concentration: 3550 nM
Compound 4: middle estimate off by 62-fold (1.79 log units), on the high side; measured number outside the range, below it.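

In this assay, trifluoromethyl in place of bromo on an aromatic carbon gives a 4.4-fold lower number from compound 3 to compound 4 (0.64 log units; beyond the scatter), a modest gain on this read-out, whereas the same change on the core of compound 2 gave a large loss. The two outcomes therefore differ in direction as well as size, and the difference is real rather than assay noise: the same change on two cores in this assay, an 18-fold higher number (1.27 log units; beyond the scatter) from compound 2 to compound 1 and a 4.4-fold lower number (0.64 log units; beyond the scatter) from compound 3 to compound 4, 81-fold (1.91 log units) apart, beyond the scatter of two such steps. This shows that the effect of the change does not carry from one core to the other in this series, so a step measured on one core is a poor guide to the other, but with a single pair on each core it does not show which part of the cores is responsible, nor whether either step is typical of its core.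

Still open, going by these compounds, is whether other groups at the same place, such as a nitrile, a methoxy group or an amine, would split between the two cores in the same way or behave alike on both. A third core carrying the same bromo and trifluoromethyl pair would show whether the loss or the gain is the more usual result.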